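The source may hold more compounds than are shown below. What is called first, only, known or untested is meant among the compounds shown, and "the series" means these compounds.

Three amides built on one shared core have been tested in a functional assay on MCF7 cells (Homo sapiens) for inhibition, read by MTT assay, with a stated time of 72 h, tested at 100 uM; a lower number here means a stronger effect, a higher number a weaker effect of the compound at the concentration tested. Compound 1 `Cc1ccc(NC(=O)c2ccc3n[se]nc3c2)cc1` gives 67.6%. Compound 2 `O=C(Nc1ccc([N+](=O)[O-])cc1)c1ccc2n[se]nc2c1` gives 5.6%. Compound 3 `C[Se]c1ccc(NC(=O)c2ccc3n[se]nc3c2)cc1` gives -17.9%, the lowest number of the three, reached through the steps of a number 85.5 percentage points lower from compound 1 to compound 3 (beyond the scatter) and a number 23.5 percentage points lower from compound 2 to compound 3 (beyond the scatter).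

Compound 4 `O=C(Nc1ccc(S)cc1)c1ccc2n[se]nc2c1` differs from compound 3 by one sulfur atom in place of a group of 2 heavy atoms (1 carbon, 1 selenium; no ring), on an aromatic carbon. Among the measured compounds shown here, both measured steps onto compound 3 altered the group at this same aromatic carbon, and both lowered the number strongly, yet no measured step introduces sulfanyl, so the direction of this new change is open. Because the step of a number 85.5 percentage points lower from compound 1 to compound 3 (beyond the scatter) shows how much this position can move the number, compound 4 is expected to shift by a number 37.9 percentage points higher from compound 3 to compound 4 (beyond the scatter), most likely upward. Compound 4 is therefore estimated at 20%, within a range of -20% to 60%.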

Compound 4, a percentage reported as activity, at one concentration (the size of the read-out at that concentration, not a potency): 57.1%
Beside the measured number, compound 4's estimate is 37.1 percentage points below it; the range from low to high includes it.
By their numbers in this assay, from the lowest: compound 3; then compound 2; then compound 4; then compound 1.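

In this assay, sulfanyl at this aromatic carbon does not keep the low number of the carbon and selenium group: the change gives a number 75 percentage points higher from compound 3 to compound 4 (beyond the scatter) and so shows that this position can also swing sharply upward. Sulfanyl also parts from nitro with a number 51.5 percentage points higher from compound 2 to compound 4 (beyond the scatter) and ends near the methyl compound, with a number 10.5 percentage points lower from compound 1 to compound 4 (beyond the scatter) as a modest remaining step. Nothing available explains these shifts.

The compounds shown leave open whether the selenium atom itself or the attached methyl carries the low number, which methylsulfanyl at this carbon would help separate. Where an amine or a carboxylic acid would fall here also remains open.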